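Replacing the phenyl group of compound 2

A few compounds are considered here, and "the series" means these few. Any claim that something is new, unique, unknown or untested is made for them only; others in the source may bear on it.

In a functional assay on MCF7 cells (Homo sapiens) for inhibition, read by MTT assay, with a stated time of 48 h (on this read-out lower numbers stand for stronger inhibition of growth and higher numbers for weaker inhibition of growth), compound 1 `COc1ccc(C(=O)N2N=C(c3ccccc3)CC2c2cn(C)c3ccccc23)cn1` gives 4310 nM, compound 2 `Cc1ccc(C(=O)N2N=C(c3ccccc3)CC2c2cn(C)c3ccccc23)cn1` gives 4010 nM and compound 3 `Cn1cc(C2CC(c3ccccc3)=NN2C(=O)c2ccncc2)c2ccccc21` gives 1110 nM. Compound 2 holds the second highest of these numbers, though a 1.1-fold lower number from compound 1 to compound 2 (0.03 log units; within the scatter) separates it from its nearest neighbour. Compound 4 `COc1cc(C2=NN(C(=O)c3ccc(C)nc3)C(c3cn(C)c4ccccc34)C2)cc(OC)c1OC` differs from compound 2 by having 3,4,5-trimethoxyphenyl in place of phenyl on a carbon with a double bond to nitrogen. Among the compounds with values here, no measured step changes this place. All of them alter the group on the carbonyl carbon, and the largest, a 3.9-fold lower number from compound 1 to compound 3 (0.59 log units; beyond the scatter), is modest, as is a 3.6-fold lower number from compound 2 to compound 3 (0.56 log units; beyond the scatter). No shift beyond the scatter is therefore expected in this assay, and the estimated step is a 1.3-fold lower number from compound 2 to compound 4 (0.13 log units; within the scatter). Compound 4 is expected at 3000 nM, within an estimated range of 900 nM to 9000 nM.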

Compound 4, concentration for 50% growth inhibition: 180 nM
Compound 4: middle estimate off by 17-fold (1.22 log units), on the high side, and the stated range ends above it.
By their numbers in this assay, from the lowest: compound 4; then compound 3; then compounds 2 and 1 (each within the scatter of the next).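

In this assay the group on the carbon with a double bond to nitrogen proves a far stronger lever than the carbonyl side: 3,4,5-trimethoxyphenyl in place of phenyl gives a 22-fold lower number from compound 2 to compound 4 (1.35 log units; beyond the scatter), a large step that exceeds the biggest change seen on the carbonyl carbon (a 3.9-fold lower number from compound 1 to compound 3 (0.59 log units; beyond the scatter)). Nothing at hand accounts for the size of this step. The compounds shown leave open whether a single methoxy group, a hydroxyl or a chlorine on the phenyl ring would give a similar gain. They also leave open whether the change would carry over to compound 3, with its pyridin-4-yl group on the carbonyl carbon.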